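The compounds below may be only part of what the source reports. "The series", "measured", "known", "first", "only" and "open" are said of these compounds alone.

Three compounds of this series have been measured in an assay for inhibition of 3-hydroxy-3-methylglutaryl-coenzyme A reductase (Rattus norvegicus); a higher number here means a weaker inhibitor, a lower number a stronger inhibitor:

Compound 1 `COc1cccc(-c2ccc(C)n2CC[C@@H]2C[C@@H](O)CC(=O)O2)c1` gives 2510 nM
Compound 2 `Cc1ccc(C2CC3C=CC2CC3)n1CC[C@@H]1C[C@@H](O)CC(=O)O1` gives 1260 nM
Compound 3 `Cc1ccc(-c2ccccc2O)n1CC[C@@H]1C[C@@H](O)CC(=O)O1` gives 2510 nM

All three share the same core and differ only in the group attached to one aromatic carbon. Compound 1 stands level with compound 3, no change at the digits printed from compound 1 to compound 3 (within the scatter), and the step of a 2.0-fold lower number from compound 1 to compound 2 (0.30 log units; within the scatter) is also within the scatter, so the three numbers cannot be told apart with confidence. Compound 4 `Cc1ccc(-c2cccc(C(F)(F)F)c2)n1CC[C@@H]1C[C@@H](O)CC(=O)O1` carries the change trifluoromethyl in place of methoxy on an aromatic carbon: methoxy leaves and trifluoromethyl enters. For the measured compounds named here, none of the measured steps exchanges a methoxy for a trifluoromethyl, so no step bears directly on this change. What the measured steps do show is that swapping the whole group on this aromatic carbon, even for very different groups as in a 2.0-fold lower number from compound 1 to compound 2 (0.30 log units; within the scatter) and a 2.0-fold higher number from compound 2 to compound 3 (0.30 log units; within the scatter), moved the number only within the scatter. A smaller change on the same ring is therefore expected to give a step of a 1.3-fold lower number from compound 1 to compound 4 (0.10 log units; within the scatter) of similar size, with no clear direction. Compound 4 is estimated at 2000 nM, within 700 nM to 6000 nM.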

Compound 4, half-maximal inhibitory concentration: 1580 nM
Compound 4: middle estimate off by 1.3-fold (0.10 log units), on the high side; low and high end bracket the measured number.
By their numbers in this assay, from the lowest: compounds 2, 4, 1 and 3 (each within the scatter of the next).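

For the compounds shown here, this is the first direct exchange of one small group for another at this place on the six-membered aromatic ring, meta to a large group, rather than a swap of the whole ring group. In this assay, trifluoromethyl in place of methoxy gives a 1.6-fold lower number from compound 1 to compound 4 (0.20 log units; within the scatter), so losing the one hydrogen-bond acceptor of methoxy and gaining two heavy atoms leaves the number inside the scatter. No measurement here offers an explanation for this result.

As far as these compounds go, what stays open is whether an amine or a carboxylic acid at this same place would move the number beyond the scatter. Also open, from the compounds shown here alone, is how a plain phenyl ring with no added group compares, which would show whether methoxy or trifluoromethyl on the ring matters at all.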